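A few compounds are considered here, and "the series" means these few. Any claim that something is new, unique, unknown or untested is made for them only; others in the source may bear on it.

Measured compounds in a physicochemical assay for metabolic stability, read by LC-MS, in simulated gastric fluid, with a stated time of 15 min, tested at 50 uM; on this read-out higher numbers stand for a more stable compound and lower numbers for a less stable compound:

Compound 1, `O=C(OCc1ccccc1)c1coc(-c2ccccc2)n1`, gives 1.8%.
Compound 2, `O=C(OCc1ccccc1)c1coc(-c2ccccc2Cl)n1`, gives 1.1%.

Of the two numbers recorded in this assay, compound 2 stands lowest, but the step of a number 0.7 percentage points lower from compound 1 to compound 2 (within the scatter) is within the scatter, so the two compounds cannot be told apart on this read-out. Both sit at the bottom of the percentage range, with very little of either compound remaining.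

Compound 3, `O=C(OCc1ccccc1)c1coc(-c2ccccc2OCc2ccccc2)n1`, has not yet been measured in this assay. It differs from compound 2 by benzyloxy in place of chloro on an aromatic carbon. Among the compounds with values here, only one measured step bears on this change, the step from compound 1 to compound 2, and that step was within the scatter. Within the data shown here, nothing in the recorded numbers separates the two substitution patterns tried so far, and no step with a benzyloxy group exists here to draw on.

Compound 3 is therefore expected to remain close to compound 2, with a step of a number 0.9 percentage points higher from compound 2 to compound 3 (within the scatter) that is expected to stay within the scatter. The estimate for compound 3 in this assay is 2%, with a range from 0.3% to 10%.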

Compound 3, percent of the compound remaining: 2.9%
For compound 3 the middle estimate is 0.9 percentage points below the measured one, within the range that was stated.
By their numbers in this assay, from the lowest: compounds 2, 1 and 3 (each within the scatter of the next).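

In this assay, the aromatic carbon ortho to a large group now carries a much larger substituent than before, benzyloxy with its 8 heavy atoms and its own six-membered aromatic ring of carbon only, yet the exchange for chloro gives a number 1.8 percentage points higher from compound 2 to compound 3 (within the scatter) and the exchange for hydrogen gives a number 1.1 percentage points higher from compound 1 to compound 3 (within the scatter), so neither step separates the compounds. Hydrogen, chloro and benzyloxy at this carbon therefore cannot be told apart on this read-out, and a group of this size has now been carried at this position with no change that the read-out can resolve. The data offer no measured explanation for the low values or for the absence of any separation.

Going by these compounds, it remains open whether any group at this carbon, such as an amine or a carboxylic acid, could lift the value clear of the bottom of the percentage range. On these data alone, it is equally open whether a change elsewhere on the shared core, such as an amide in place of the ester, would do so.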